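Nitrophenyl for Chlorophenyl on a Weakly Active Triazine

This account rests on a few compounds, and the source may have more. Where it says the series, first, only, none or still open, it means among the compounds named here.

Of the compounds shown here, two have so far been measured in a functional assay on MCF7 cells (Homo sapiens) for cytotoxicity, read by MTT assay, with a stated time of 24 h; a higher number here means a weaker inhibitor, a lower number a stronger inhibitor. Compound 1 `O=C(CN1CCN(c2cccc(Cl)c2)CC1)N1CCN(c2nnc(-c3ccccc3)c(-c3ccccc3)n2)CC1` gives 56300 nM. Compound 2 `Cc1ccc(-c2nnc(N3CCN(C(=O)CN4CCN(c5ccccc5Cl)CC4)CC3)nc2-c2ccc(C)cc2)cc1` gives 859000 nM, the higher of the two numbers, and its distance from compound 1 lies beyond the usual scatter. These two compounds differ in more than one place, so the pair alone does not show which part of the structure carries the difference.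

Compound 3 `Cc1ccc(-c2nnc(N3CCN(C(=O)CN4CCN(c5ccc([N+](=O)[O-])cc5)CC4)CC3)nc2-c2ccc(C)cc2)cc1` departs from compound 2 in one place: 4-nitrophenyl in place of 2-chlorophenyl on an amine nitrogen in a ring. Among the compounds with values here, no measured pair isolates this change, so the expectation rests on compound 2 alone. Since compound 2 gives 859000 nM in this assay, compound 3 is expected to remain weak, with a step of a 1.4-fold lower number from compound 2 to compound 3 (0.16 log units; within the scatter) of no certain direction and probably not beyond the scatter. Compound 3 is therefore estimated at 600000 nM, within 150000 nM to 2000000 nM.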

Compound 3, half-maximal inhibitory concentration: 845000 nM
Compound 3: middle estimate off by 1.4-fold (0.15 log units), on the low side; the range from low to high includes it.
By their numbers in this assay, from the lowest: compound 1; then compounds 3 and 2 (each within the scatter of the next).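

Replacing 2-chlorophenyl with 4-nitrophenyl on the amine nitrogen in the ring gives a 1.0-fold lower number from compound 2 to compound 3 (0.01 log units; within the scatter) in this assay, the first single-place step available in this set. On the core of compound 2, this position therefore takes a group with more heavy atoms and with hydrogen-bond acceptors, and the reading stays where it was, so this change offers no gain in strength. Nothing measured here accounts for so small a step.

Compound 1 differs from compound 2 and from compound 3 in more than one place, so what sets it apart from them remains unresolved. Also open, going by these compounds, is whether an amine or a carboxylic acid on that phenyl ring would leave the reading equally unchanged, or whether this position can move the number at all.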